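Shortening the linker chain: compound 1 to compound 4

The source may report more compounds than this note shows. Statements on the series, on what has been measured and on what is new or still open speak of the compounds shown alone.

Values in an assay on Flp-In-CHO cells for displacement of a labelled ligand from adenosine receptor A1 (Homo sapiens), read by radioligand binding; a higher number here means a weaker inhibitor, a lower number a stronger inhibitor:
compound 1 `CCCn1c(=O)c2[nH]c(C34CCC(C(=O)NCCNC(=O)COCCOCCNC(=O)OC(C)(C)C)(CC3)CC4)nc2n(CCC)c1=O` — 17.4 nM
compound 2 `CCCn1c(=O)c2[nH]c(C34CCC(C(=O)NCCCNC(=O)COCCOCCNC(=O)OC(C)(C)C)(CC3)CC4)nc2n(CCC)c1=O` — 22.4 nM
compound 3 `CCCn1c(=O)c2[nH]c(C34CCC(CCC(=O)NCCNC(=O)COCCNC(=O)OC(C)(C)C)(CC3)CC4)nc2n(CCC)c1=O` — 14.8 nM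

Compound 1 stands second highest of the three numbers; compound 3 lies a little lower and compound 2 a little higher, both within the scatter. Compound 4 `CCCn1c(=O)c2[nH]c(C34CCC(C(=O)NCCNC(=O)COCCNC(=O)OC(C)(C)C)(CC3)CC4)nc2n(CCC)c1=O` differs from compound 1 by (tert-butoxycarbonyl)amino in place of 2-((tert-butoxycarbonyl)amino)ethoxy on a saturated chain carbon, two bonds along the chain from an oxygen on a saturated carbon: the chain is cut by one ethoxy unit while the cap is kept. Within the data shown here, no pair of measured compounds differs in one place only, so no measured step can be quoted. The chains of compounds 1, 2 and 3 already vary and their values sit within the scatter of each other. The step from compound 1 to compound 4 is therefore expected as a 1.0-fold higher number from compound 1 to compound 4 (0.01 log units; within the scatter) in this assay, none beyond the scatter. Compound 4 is estimated at 18 nM, range 9 nM to 36 nM.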

Compound 4, inhibition constant: 13.8 nM
Compound 4: the middle estimate sits 1.3-fold (0.12 log units) above what was measured; the range from low to high includes it.
By their numbers in this assay, from the lowest: compounds 4, 3, 1 and 2 (each within the scatter of the next).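

In this assay, among these compounds, removing one ethoxy unit from the chain while keeping the cap gives a 1.3-fold lower number from compound 1 to compound 4 (0.10 log units; within the scatter) as the first single-place comparison. At this saturated chain carbon, (tert-butoxycarbonyl)amino therefore reads the same as 2-((tert-butoxycarbonyl)amino)ethoxy within the scatter. No supporting data bear on the reason for this result.

The compounds shown leave open how a free amine or a carboxylic acid in place of the cap would read at this position. As far as these compounds go, it also remains open whether a longer chain with further ethoxy units would stay within the scatter.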